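This account rests on a few compounds, and the source may have more. Where it says the series, first, only, none or still open, it means among the compounds named here.

Measured so far:
compound 1 `CCCCCCCCCCc1ccc(-c2noc(CCCNC)n2)cc1`, 45%
compound 2 `CCCCCCCCCCc1ccc(-c2noc([C@@H]3CCCN3)n2)cc1`, 21%

Among the measured compounds shown here, in an assay on HeLa cells for inhibition of sphingosine-1-phosphate transporter SPNS2 (Mus musculus), read by LC-MS, tested at 2 uM (a lower number here means less inhibition, a higher number more inhibition at the concentration tested (going by the name of the read-out)), compound 2 gives 21%, the lowest of the two numbers so far; its nearest neighbour is compound 1, which in this assay gives 45%, a gap beyond the scatter. Compound 3 `CCCCCCCCCCc1ccc(-c2noc([C@@H](N)CCCCN)n2)cc1` differs from compound 2 at one place on the shared core: 1,5-diaminopentyl in place of pyrrolidin-2-yl on an aromatic carbon. For the measured compounds named here, the only measured step that bears on this is a number 24 percentage points lower from compound 1 to compound 2 (beyond the scatter), in which pyrrolidin-2-yl replaced 3-(methylamino)propyl and the number fell. Compound 3 undoes the ring and brings in a group with no ring again, so the expectation is a return toward the number of compound 1 rather than a further fall, with a step of a number 19 percentage points higher from compound 2 to compound 3 (beyond the scatter) expected in this assay. Compound 3 is therefore estimated at 40%, expected to lie between 15% and 65%.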

Compound 3, a percentage reported as inhibition, at one concentration (the size of the read-out at that concentration, not a potency): 43%
Compound 3: the middle estimate sits 3 percentage points below what was measured, within the range that was stated.
By their numbers in this assay, from the lowest: compound 2; then compounds 3 and 1 (each within the scatter of the next).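

In this assay, the change to 1,5-diaminopentyl gives a number 22 percentage points higher from compound 2 to compound 3 (beyond the scatter), so the lower number of compound 2 does not carry over to every group on this aromatic carbon. Among the compounds shown here, the change from 3-(methylamino)propyl to 1,5-diaminopentyl gives a number 2 percentage points lower from compound 1 to compound 3 (within the scatter), so these two groups without a ring cannot be told apart here, and among the three compounds only the one with pyrrolidin-2-yl stands apart. No independent evidence explains why that ring-bearing compound gives the lower number.

Going by these compounds, whether the lower number belongs to rings at this place in general or to pyrrolidin-2-yl alone stays open, and piperidin-2-yl would speak to that. It is also unclear whether 1,5-diaminopentyl needs both its amines, or how a chain ending in a carboxylic acid would compare.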